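The source may report more compounds than this note shows. Statements on the series, on what has been measured and on what is new or still open speak of the compounds shown alone.

Compound 2 `Nc1ncnn2c([C@@H]3O[C@H](CO)[C@@H](O)[C@H]3O)cc(-c3ccc(F)cc3)c12` gives 55500 nM in a functional assay on NCI-H460 cells (Homo sapiens) for antiproliferative activity, with a stated time of 72 h (a higher number here means a weaker inhibitor, a lower number a stronger inhibitor), the lowest of the two numbers seen so far; its nearest neighbour, compound 1 `Nc1ncnn2c([C@@H]3O[C@H](CO)[C@@H](O)[C@H]3O)cc(C#Cc3ccc(F)cc3)c12`, gives 79400 nM, and the step is a 1.4-fold lower number from compound 1 to compound 2 (0.16 log units; within the scatter). Compound 3 `Nc1ncnn2c([C@@H]3O[C@H](CO)[C@@H](O)[C@H]3O)cc(-c3ccccc3Cl)c12` differs from compound 2 by 2-chlorophenyl in place of 4-fluorophenyl on an aromatic carbon. Within the data shown here, no measured step exchanges one halogen-bearing phenyl for another, and the one known step concerns a different change and itself stayed within the scatter, so nothing points in either direction. Compound 3 is therefore expected to move by a 1.0-fold lower number from compound 2 to compound 3 (0.00 log units; within the scatter), giving an estimate of 55000 nM, with a range from 18000 nM to 170000 nM.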

Compound 3, half-maximal inhibitory concentration: > 100000 nM
Compound 3: no number, only a limit; the forecaster's own chance of this, stated with the estimate: 15%; middle value at least 1.8-fold (0.25 log units) from the limit.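

In this assay compound 3 gives no number, only a limit: the limit of > 100000 nM in this assay, at which 1 of the 3 values shown sits. The change to 2-chlorophenyl gives an at least 1.8-fold higher number from compound 2 to compound 3 (0.25 log units; that floor lies within the scatter), and the comparison with the ethynyl-linked group gives an at least 1.2-fold higher number from compound 1 to compound 3 (0.10 log units; that floor lies within the scatter). So this aromatic carbon has now taken a third group without a stronger result, but whether the true gap exceeds the scatter cannot be told.

On these data alone, what a 4-chlorophenyl, an unsubstituted phenyl or an amine on this carbon would give stays open. So does whether the halogen or its place on the phenyl ring matters.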